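The compounds below may be only part of what the source reports. "The series", "measured", "known", "first", "only" and "open" are said of these compounds alone.

Working notes on the series in a functional assay on aorta (strain Wistar) for inhibition, with Thoracic aorta (Rattus norvegicus) as the target; a higher number here means a weaker inhibitor, a lower number a stronger inhibitor.

Three compounds of the shared core carry a para-substituted phenyl ring on the same carbon. Compound 1 `CCOc1nc(-c2cc3ccccc3o2)cc(-c2ccc(C)cc2)c1C#N` gives 290000 nM. Compound 2 `CCOc1nc(-c2cc3ccccc3o2)cc(-c2ccc(OC)cc2)c1C#N` gives 204000 nM. Compound 3 `CCOc1nc(-c2cc3ccccc3o2)cc(-c2ccc(N(C)C)cc2)c1C#N` gives 338000 nM. The steps between them are a 1.4-fold lower number from compound 1 to compound 2 (0.15 log units; within the scatter), a 1.2-fold higher number from compound 1 to compound 3 (0.07 log units; within the scatter) and a 1.7-fold higher number from compound 2 to compound 3 (0.22 log units; within the scatter); none of them passes the scatter, so compound 3 stands among the other two rather than apart from them.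

Compound 4 `CCOc1nc(-c2cc3ccccc3o2)cc(-c2cccs2)c1C#N` is the next member. The change from compound 3 is thiophen-2-yl in place of 4-(dimethylamino)phenyl on an aromatic carbon: the whole six-membered ring with its dimethylamino group is exchanged for a five-membered ring with one sulfur, on the carbon ortho to the cyano group and opposite the ring nitrogen.

Going by the values given here, no measured step exchanges the ring itself; the three steps above only swap the group on the phenyl ring, and all three stay within the scatter. They therefore give no direction for compound 4, only the picture that this position has so far tolerated variation without any step beyond the scatter. On that basis the expectation for compound 4 is a step of a 1.1-fold lower number from compound 3 to compound 4 (0.05 log units; within the scatter), that is, no movement beyond the scatter, with the range left wide to allow for the unmeasured ring exchange. The estimate for compound 4 in this assay is 300000 nM, between 120000 nM and 750000 nM.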

Compound 4, half-maximal inhibitory concentration: 308000 nM
The estimate for compound 4 lay 1.0-fold (0.01 log units) below the measured number; the range from low to high includes it.
By their numbers in this assay, from the lowest: compounds 2, 1, 4 and 3 (each within the scatter of the next).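

In this assay, going by these compounds alone, the first exchange of the whole ring at this position can be read: thiophen-2-yl gives a 1.1-fold lower number from compound 3 to compound 4 (0.04 log units; within the scatter) in place of 4-(dimethylamino)phenyl, a 1.5-fold higher number from compound 2 to compound 4 (0.18 log units; within the scatter) in place of 4-methoxyphenyl and a 1.1-fold higher number from compound 1 to compound 4 (0.03 log units; within the scatter) in place of 4-methylphenyl in the same series. The earlier steps shown here only swapped the group on a six-membered aromatic ring of carbon only, whereas these show that, among the four compounds, a five-membered aromatic ring with one sulfur on this carbon, ortho to the cyano group and opposite the ring nitrogen, also leaves the number within the scatter, and no compound goes against this. Nothing available bears on why the number holds here.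

As far as these compounds go, whether a non-aromatic group at this carbon, such as a piperidine ring, a carboxylic acid or a longer alkyl chain, would move the number beyond the scatter stays open. Also open, from the compounds shown here alone, is whether the same flat picture holds once the ethoxy group or the 1-benzofuran-2-yl group is exchanged, for instance for a primary amine or a plain phenyl ring.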